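Shared core series: methyl for fluoro step toward compound 4

The source may hold more compounds than are shown below. What is called first, only, known or untested is meant among the compounds shown, and "the series" means these compounds.

compound 1 `CN1C[C@@H](c2ccc(F)cc2)[C@@]2(Cc3ccccc3C2=O)[C@@]12C(=O)Nc1ccccc12`: 21.8%
compound 2 `CN1C(=O)[C@@]2(c3ccccc31)N(C)C[C@@H](c1ccc(F)cc1)[C@@]21Cc2ccccc2C1=O`: 25.5%
compound 3 `CN1C[C@@H](c2ccc(Cl)cc2)[C@@]2(Cc3ccccc3C2=O)[C@@]12C(=O)Nc1ccccc12`: 15.6%

In a functional assay on the whole organism (strain Wister albino) for inhibition, with Rattus norvegicus as the target, read by paw edema, with stated times of 1 h and 4 h, at a dose of 50 mg/kg by the intraperitoneal route (a lower number here means less inhibition, a higher number more inhibition at the dose given (going by the name of the read-out)), compound 2 holds the highest of the three numbers, but the step of a number 3.7 percentage points higher from compound 1 to compound 2 (within the scatter) does not separate it from compound 1, and compound 3 gives 15.6%, a gap that also falls within the scatter. Compound 4 `Cc1ccc([C@@H]2CN(C)[C@]3(C(=O)N(C)c4ccccc43)[C@]23Cc2ccccc2C3=O)cc1` differs from compound 2 by methyl in place of fluoro on an aromatic carbon. Among the measured compounds shown here, the only step at that aromatic carbon is a number 6.2 percentage points lower from compound 1 to compound 3 (within the scatter), which did not exceed the scatter. No change beyond the scatter is therefore expected for a number 1.5 percentage points lower from compound 2 to compound 4 (within the scatter). Compound 4 is estimated at 24%, with a range from 14% to 34%.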

Compound 4, a percentage reported as inhibition, in the whole organism at one dose (the size of the read-out at that dose, not a potency): 13.9%
The estimate for compound 4 lay 10.1 percentage points above the measured number; measured number outside the range, below it.
By their numbers in this assay, from the lowest: compounds 4, 3, 1 and 2 (each within the scatter of the next, the first and the last beyond it).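

In this assay, among the compounds shown here, the change from 4-fluorophenyl to 4-methylphenyl gives a number 11.6 percentage points lower from compound 2 to compound 4 (beyond the scatter), the only step at this aromatic carbon that goes beyond the scatter. The replacement of fluoro by chloro in a number 6.2 percentage points lower from compound 1 to compound 3 (within the scatter) did not, so this carbon is not indifferent to every replacement of fluoro. No measurement given here accounts for the step.

Still open, on these data alone, is whether a methoxy or an amine at this carbon would follow methyl. Also open, as far as these compounds go, is whether methyl gives a similar step with the amide hydrogen of compound 1 in place.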